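The compounds below may be only part of what the source reports. "The series", "measured", "known", "first", "only" and "open" are said of these compounds alone.

Of the compounds shown here, three have so far been tested in an ADME assay on Vero cells (Chlorocebus sabaeus) for cytotoxicity, read by MTT assay, with a stated time of 48 h (on this read-out lower numbers stand for stronger inhibition and higher numbers for weaker inhibition), and all three come back without a number. Compound 1 `O=c1nc(NCc2cccc(F)c2)oc2c([N+](=O)[O-])cc(C(F)(F)F)cc12` gives only a limit, > 64 ug/mL. Compound 2 `O=c1cc(NCc2cccc(F)c2)sc2c([N+](=O)[O-])cc(C(F)(F)F)cc12` likewise gives only a limit, > 64 ug/mL. Compound 3 `O=C1CN(c2cc(=O)c3cc(C(F)(F)F)cc([N+](=O)[O-])c3s2)CCN1CC1CCCCC1` also gives only a limit, > 64 ug/mL. Compound 2 thus stands exactly where every measured value stands, at the limit of > 64 ug/mL in this assay, at which 3 of the 3 values shown sit, so nothing on these numbers sets it apart from the other two.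

Compound 4 `CN(Cc1ccccc1)c1cc(=O)c2cc(C(F)(F)F)cc([N+](=O)[O-])c2s1` has not yet been measured. It differs from compound 2 in one place: benzyl(methyl)amino in place of (3-fluorobenzyl)amino on an aromatic carbon. Among the compounds with values here, no pair of measured compounds differs in only one place, so no measured step shows how far such a change can move this assay. Because every value on hand sits at the limit of > 64 ug/mL in this assay, at which 3 of the 3 values shown sit, the step is expected to be none beyond the usual scatter, a step that the limit leaves unreadable from compound 2 to compound 4. Compound 4 is therefore expected to give around 80 ug/mL in this assay, within a range from 40 ug/mL to 160 ug/mL, and the result will most likely again be a limit rather than a number.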

Compound 4, half-maximal inhibitory concentration: > 64 ug/mL
Compound 4: no number, only a limit (the forecaster's own chance of this, stated with the estimate: 75%); the middle value is on the limit's open side.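

No step can be read from compound 2 to compound 4, since both give only a limit and not a number: the limit of > 64 ug/mL in this assay, at which 4 of the 4 values shown sit.

The compounds shown leave open whether benzyl(methyl)amino in place of (3-fluorobenzyl)amino shifts the result in this assay at all, and what actual number any of the four compounds would give there.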